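The source may hold more compounds than are shown below. What is called first, only, known or untested is meant among the compounds shown, and "the series" means these compounds.

Working notes on the series, read in a functional assay on MDA-MB-231 cells (Homo sapiens) for cytotoxicity, read by MTT assay, with a stated time of 72 h; a higher number here means a weaker inhibitor, a lower number a stronger inhibitor. Compound 3 `CN(C)Cc1ccc2nc(NC(=O)N/N=C/c3cn(Cc4cccc(Cl)c4)c4ccccc34)sc2c1` gives 1140 nM, which lies within the scatter of compound 2 `CN(C)Cc1ccc2nc(NC(=O)N/N=C/c3cn(Cc4ccc(Cl)cc4)c4ccccc34)sc2c1` at 880 nM. Set against compound 3, compound 1 `CC1CCN(Cc2ccc3nc(NC(=O)N/N=C/c4cn(Cc5ccc(Cl)cc5Cl)c5ccccc45)sc3c2)CC1` stands well apart, with the higher number of 3140 nM.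

The next change leads from compound 3 to compound 4 `CN(C)Cc1ccc2nc(NC(=O)N/N=C/c3cn(Cc4ccc(Cl)cc4Cl)c4ccccc34)sc2c1`: 2,4-dichlorophenyl in place of 3-chlorophenyl on a saturated chain carbon bound to an aromatic nitrogen. In words, 2,4-dichlorophenyl takes the place of 3-chlorophenyl on a saturated chain carbon bound to an aromatic nitrogen, and the rest of the structure stays the same.

One measured step changes this same place: a 1.3-fold higher number from compound 2 to compound 3 (0.11 log units; within the scatter). It swaps 4-chlorophenyl for 3-chlorophenyl and stays within the scatter. Compound 1 already carries the 2,4-dichlorophenyl group, but it also differs from compound 4 elsewhere, so the data do not isolate the contribution of this group. Going by the values given here, no measured pair tests the added chlorine alone.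

Given the small step of a 1.3-fold higher number from compound 2 to compound 3 (0.11 log units; within the scatter), no shift beyond the scatter is expected in this assay. The range is left wider toward higher numbers in view of compound 1 at 3140 nM. The expected step is a 1.1-fold higher number from compound 3 to compound 4 (0.06 log units; within the scatter). Compound 4 is estimated at 1300 nM, with an expected range from 550 nM to 3000 nM.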

Compound 4, half-maximal inhibitory concentration: 1410 nM
Compound 4: middle estimate off by 1.1-fold (0.04 log units), on the low side, and the stated range covers the measured number.
By their numbers in this assay, from the lowest: compounds 2, 3 and 4 (each within the scatter of the next); then compound 1.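

In this assay, the change from 3-chlorophenyl to 2,4-dichlorophenyl gives a 1.2-fold higher number from compound 3 to compound 4 (0.09 log units; within the scatter), and chloro in place of hydrogen on an aromatic carbon, now tested as a single change, gives a 1.6-fold higher number from compound 2 to compound 4 (0.20 log units; within the scatter), so the 4-chlorophenyl, 3-chlorophenyl and 2,4-dichlorophenyl groups are not told apart in this assay. Going by these compounds alone, compound 4 also provides the pair that holds 2,4-dichlorophenyl constant: dimethylamino in place of 4-methylpiperidin-1-yl on a saturated chain carbon bound to an aromatic carbon gives a 2.2-fold lower number from compound 1 to compound 4 (0.35 log units; beyond the scatter), the only new step beyond the scatter, which places the larger difference at the amine rather than at the chlorophenyl group. No supporting evidence is available to explain any of these steps.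

From the compounds shown here alone, it remains open whether a group without chlorine, such as unsubstituted phenyl or methoxyphenyl, on a saturated chain carbon bound to an aromatic nitrogen would move the number beyond the scatter. Going by these compounds, it is equally open how a morpholine or piperazine would compare with dimethylamino and 4-methylpiperidin-1-yl on a saturated chain carbon bound to an aromatic carbon.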